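Trifluoromethyl in place of methylsulfanyl on compound 3

The source may report more compounds than this note shows. Statements on the series, on what has been measured and on what is new or still open speak of the compounds shown alone.

Compound 1 (`Cc1cc(NC(=O)Nc2ccccc2N)c2ccccc2n1`) gives > 25000 nM as a limit
Compound 2 (`COC(=O)c1ccc(NC(=O)Nc2cc(C)nc3ccccc23)cc1`) gives 17000 nM as a number
Compound 3 (`CSc1ccccc1NC(=O)Nc1cc(C)nc2ccccc12`) gives > 25000 nM as a limit

Among the compounds with values here, in an ADME assay on Raji cells (Homo sapiens) for cytotoxicity, with a stated time of 72 h (on this read-out higher numbers stand for an effect only at larger amounts of compound and lower numbers for an effect already at smaller amounts), the picture is shaped by the limit of > 25000 nM in this assay, at which 2 of the 3 values shown sit, and only one reading is a number. Compound 3 stands at > 25000 nM and this is a limit of the assay, not a number. Compound 4 (`Cc1cc(NC(=O)Nc2ccccc2C(F)(F)F)c2ccccc2n1`) carries trifluoromethyl in place of methylsulfanyl on an aromatic carbon, ortho to a large group. Within the data shown here, the one measured step that touches the methylsulfanyl group is a step that the two limits leave unreadable from compound 1 to compound 3 and it offers no size to carry over. Among the measured compounds shown here, compound 2 at 17000 nM shows only that a number can appear for these compounds in this assay at all. No step beyond the scatter, in either direction, is therefore expected. The expected change is an at least 1.1-fold lower number from compound 3 to compound 4 (0.05 log units; that floor lies within the scatter) in this assay on present evidence. Compound 4 is estimated at 22000 nM with an expected range from 10000 nM to 25000 nM in this read-out.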

Compound 4, half-maximal effective concentration: > 25000 nM
Compound 4: only a limit was reported; the forecaster's own chance of this, stated with the estimate: 60%; at least 1.1-fold (0.05 log units) between middle value and limit.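

Compound 4 gives > 25000 nM, which is a limit and not a number. Compound 1 and compound 3 also stand at limits, and the steps from either of them to compound 4 cannot be read. The compounds shown leave open whether amino, methylsulfanyl and trifluoromethyl differ at all in cytotoxicity.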